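Lengthening the chain on compound 3

The compounds below may be only part of what the source reports. "The series", "measured", "known", "first", "only" and "open" are said of these compounds alone.

Measured so far in a functional assay on EC9706 cells (Homo sapiens) for antiproliferative activity, read by MTT assay, with a stated time of 48 h; on this read-out lower numbers stand for stronger inhibition and higher numbers for weaker inhibition
- Compound 1 `CCCCCCCn1cc(COC[C@@H]2OC[C@H](N)[C@@H]2O)nn1` gives > 128000 nM, which is a limit
- Compound 2 `CCCCCCCCCCCCCCCCCCn1cc(COC[C@@H]2OC[C@H](N)[C@@H]2O)nn1` gives 17800 nM
- Compound 3 `CCCCCCCn1cc(COC[C@@H]2OC[C@H](N)[C@H]2O)nn1` gives > 128000 nM, which is a limit

Compound 3 stands at > 128000 nM, a limit and not a number. Compound 4 `CCCCCCCCCCn1cc(COC[C@@H]2OC[C@H](N)[C@H]2O)nn1` differs from it by propyl in place of hydrogen on a saturated chain carbon, seven bonds along the chain from an aromatic nitrogen. The closest guide is a larger addition at the same place, which gave an at least 7.1-fold lower number from compound 1 to compound 2 (0.85 log units; beyond the scatter). For the measured compounds named here, the only measured step on configuration, a step that the two limits leave unreadable from compound 1 to compound 3, cannot show whether compound 3 would respond alike, as both values sit at the limit of > 128000 nM in this assay, at which 2 of the 3 values shown sit. In this assay, a smaller fall in the number is therefore expected, and compound 4 may yet stay at the limit. The expected change is an at least 2.1-fold lower number from compound 3 to compound 4 (0.32 log units; beyond the scatter). For compound 4 the estimated value is 60000 nM, with an expected range from 25000 nM to 150000 nM.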

Compound 4, half-maximal inhibitory concentration: 43100 nM
Estimate against measurement, compound 4: 1.4-fold (0.14 log units) above, and the stated range covers the measured number.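

In this assay, propyl in this place gives an at least 2.9-fold lower number from compound 3 to compound 4 (0.47 log units; beyond the scatter). This brings the configuration of compound 3 off its limit to a measured number. A longer chain at this place therefore lowers the number on this configuration too, not only on that of compound 1.

Going by these compounds, what configuration alone does stays unreadable, because compound 1 and compound 3 share one limit: the limit of > 128000 nM in this assay, at which 2 of the 4 values shown sit. Also open is whether a carboxylic acid in place of propyl would lower the number as well.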